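Swapping a Methoxypyridyl for Pyridin-4-yl: Solubility Expected to Rise

The compounds below may be only part of what the source reports. "The series", "measured", "known", "first", "only" and "open" are said of these compounds alone.

For the measured compounds named here, in a physicochemical assay for solubility, using the shake flask method, in phosphate buffer, with a stated time of 24 h, at pH 7.2 (a higher number here means a more soluble compound, a lower number a less soluble compound), compound 2 `COc1ccc(-c2c(C3CCCC3)c3ccc(C(=O)NC4(C(=O)Nc5ccc(/C=C/C(=O)O)cc5)CCC4)cc3n2C)cn1` gives 0.6 ug/mL, the lowest of the three numbers measured so far. Compound 1 `Cn1c(-c2ccc(Cl)cn2)c(C2CCCC2)c2ccc(C(=O)NC3(C(=O)Nc4ccc(/C=C/C(=O)O)cc4)CCCC3)cc21` gives 4 ug/mL, and compound 3 `Cn1c(-c2ccncc2)c(C2CCCC2)c2ccc(C(=O)NC3(C(=O)Nc4ccc(/C=C/C(=O)O)cc4)CCCC3)cc21` gives 11 ug/mL, both beyond the scatter above compound 2. The new compound 4 `Cn1c(-c2ccncc2)c(C2CCCC2)c2ccc(C(=O)NC3(C(=O)Nc4ccc(/C=C/C(=O)O)cc4)CCC3)cc21` differs from compound 2 in one place: pyridin-4-yl in place of 6-methoxypyridin-3-yl on an aromatic carbon.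

Going by the values given here, only one measured step bears on this change. It is a 2.8-fold higher number from compound 1 to compound 3 (0.44 log units; beyond the scatter), where pyridin-4-yl likewise enters in place of a substituted pyridyl on the same aromatic carbon of the shared core. That step was modest but real, and the group leaving compound 2 carries, like the group leaving compound 1, a substituent that pyridin-4-yl lacks. A step of similar size and direction is therefore expected for compound 4, namely a 3.3-fold higher number from compound 2 to compound 4 (0.52 log units; beyond the scatter). Compound 4 is thus estimated at 2 ug/mL in this assay, with a plausible range from 0.8 ug/mL to 6 ug/mL.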

Compound 4, solubility: 7 ug/mL
Compound 4: the middle estimate sits 3.5-fold (0.54 log units) below what was measured; the measured number lies above the stated range.
By their numbers in this assay, from the lowest: compound 2; then compounds 1, 4 and 3 (each within the scatter of the next, the first and the last beyond it).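

In this assay the exchange of 6-methoxypyridin-3-yl for pyridin-4-yl gives a 12-fold higher number from compound 2 to compound 4 (1.07 log units; beyond the scatter) and that step is large, whereas the earlier exchange on this aromatic carbon, with 5-chloropyridin-2-yl leaving, gave the modest 2.8-fold higher number from compound 1 to compound 3 (0.44 log units; beyond the scatter). Both steps run upward, so across these two pairs the entry of pyridin-4-yl raises the number, and how far it rises differs with the group that leaves and the compound pair in which the exchange is made. Nothing shown here accounts for the size of the new step.

The new step removes the methoxy group and also changes the point of attachment of the pyridine ring, and the compounds shown do not separate these two changes. A plain pyridin-3-yl on this carbon would separate them, and a 6-aminopyridin-3-yl would show whether another group in the place of methoxy behaves alike.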